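A few compounds are considered here, and "the series" means these few. Any claim that something is new, unique, unknown or untested is made for them only; others in the source may bear on it.

Of the compounds shown here, three that share one core have been measured in an assay on isolated protein for binding affinity to Equilibrative nucleoside transporter 1 (Homo sapiens); a lower number here means a stronger inhibitor, a higher number a weaker inhibitor. Compound 1 `OC[C@H]1O[C@@H](n2cnc3c(SCC4CCCCC4)ncnc32)[C@H](O)[C@@H]1O` gives 1550 nM, compound 2 `CCSc1ncnc2c1ncn2[C@@H]1O[C@H](CO)[C@@H](O)[C@H]1O` gives 57500 nM, and compound 3 `O=[N+]([O-])c1ccc(O)c(CSc2ncnc3c2ncn3[C@@H]2O[C@H](CO)[C@@H](O)[C@H]2O)c1` gives 33.1 nM. Compound 3 therefore holds the lowest number of the three: the step of a 47-fold lower number from compound 1 to compound 3 (1.67 log units; beyond the scatter) and the step of a 1700-fold lower number from compound 2 to compound 3 (3.24 log units; beyond the scatter) both run toward it, while the step of a 37-fold higher number from compound 1 to compound 2 (1.57 log units; beyond the scatter) separates the other two. Compound 4 `CC(C)c1ccc(CSc2ncnc3c2ncn3[C@@H]2O[C@H](CO)[C@@H](O)[C@H]2O)cc1` has not been measured. It differs from compound 3 in one place: 4-isopropylphenyl in place of 2-hydroxy-5-nitrophenyl on a saturated chain carbon bound to a sulfur. The measured steps that bear on this change are the two leading into compound 3, since each replaced a group on the same carbon with the 2-hydroxy-5-nitrophenyl group that now leaves, and both were large. Compound 4 keeps a six-membered aromatic ring of carbon only on that carbon but carries none of the hydrogen-bond donors or acceptors counted for the leaving group. Compound 1, with a cyclohexyl group on that carbon, stands at 1550 nM. A step upward in this assay, well beyond the scatter, is therefore expected: a 9.1-fold higher number from compound 3 to compound 4 (0.96 log units; beyond the scatter). Compound 4 is estimated at 300 nM, within the range 60 nM to 1500 nM.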

Compound 4, half-maximal inhibitory concentration: 4790 nM
Compound 4: the middle estimate sits 16-fold (1.20 log units) below what was measured, outside the stated range (above it).
By their numbers in this assay, from the lowest: compound 3; then compound 1; then compound 4; then compound 2.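

The earlier compounds shown here could suggest that a six-membered aromatic ring of carbon only on the saturated chain carbon bound to a sulfur was enough for a low number in this assay, but a 140-fold higher number from compound 3 to compound 4 (2.16 log units; beyond the scatter) shows that it is not, and that what the ring carries on it can matter by a large margin. The 4-isopropylphenyl group still holds a clear advantage over methyl, with a 12-fold lower number from compound 2 to compound 4 (1.08 log units; beyond the scatter), yet it gives no gain over the saturated ring, with a 3.1-fold higher number from compound 1 to compound 4 (0.49 log units; beyond the scatter), a modest step that runs the other way. The aromatic ring alone therefore does not set the order, since the two compounds that have one fall on opposite sides of the cyclohexyl compound, and nothing given here offers a measured explanation for this gap.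

The hydroxyl, the nitro group and the isopropyl group all differ together in this comparison, so the compounds shown leave open which of them accounts for the large step. A plain phenyl group on that carbon, or a phenyl ring carrying only a hydroxyl or only a nitro group, would be needed to separate their contributions.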